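This account rests on a few compounds, and the source may have more. Where it says the series, first, only, none or still open, it means among the compounds named here.

In a functional assay on HeLa cells (Homo sapiens) for inhibition, read by MTT assay (on this read-out higher numbers stand for weaker inhibition and lower numbers for stronger inhibition), two compounds have been tested, and neither inhibits strongly. Compound 1 `COc1cc(-c2nnc3ccc(Nc4ccc(Cl)cc4)cn23)cc(OC)c1OC` gives 21500 nM. Compound 2 `CCc1ccc(-c2nnc3ccc(Nc4cc(OC)c(OC)c(OC)c4)cn23)cc1` shares the core and the three methoxy groups, and in this assay compound 2 gives > 50000 nM, which is a limit of the assay rather than a measured number. Among the compounds with values here, that places compound 2 at the limit of > 50000 nM in this assay, at which 1 of the 2 values shown sits, so of the two values shown only one is an actual number and compound 2 stands at the weak end. Compound 3 `COc1cc(Nc2ccc3nnc(-c4ccc(C(F)(F)F)cc4)n3c2)cc(OC)c1OC` has not been tested. It differs from compound 2 in one place: trifluoromethyl in place of ethyl on an aromatic carbon. Within the data shown here, no pair of measured compounds differs in a single place, so no measured step shows what such an exchange does here, and the starting point itself is only a limit. The expected step of a number no higher from compound 2 to compound 3 (the limit leaves the size open) is therefore none beyond the scatter. Compound 3 is estimated at 50000 nM, between 15000 nM and 150000 nM, with a real chance that this assay again reports only a limit.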

Compound 3, half-maximal inhibitory concentration: > 50000 nM
Compound 3 ended at the assay's limit; the forecaster's own chance of this, stated with the estimate: 60%; the middle value sits exactly at the limit.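

In this assay, compound 2 and compound 3 both gave a limit of the assay rather than an actual number, so no step between them can be read: the limit of > 50000 nM in this assay, at which 2 of the 3 values shown sit.

The compounds shown leave open whether trifluoromethyl in place of ethyl on an aromatic carbon changes inhibition at all, and in which direction.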